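The compounds below may be only part of what the source reports. "The series", "measured", "known", "first", "only" and "open" are said of these compounds alone.

Measured in a functional assay on HeLa cells (Homo sapiens) for antiproliferative activity, read by CCK-8 assay, with a stated time of 72 h, tested at 8 uM; a lower number here means a weaker effect, a higher number a stronger effect of the compound at the concentration tested:
compound 1 `Nc1ccccc1NC(=O)c1ccc(CSC(=S)N2CCN(c3ccc(Cl)cc3)CC2)cc1` — 44.8%
compound 2 `Nc1ccccc1NC(=O)c1ccc(CSC(=S)N2CCc3ccccc32)cc1` — 67%
compound 3 `Nc1ccccc1NC(=O)c1ccc(CSC(=S)N2CCN(c3ccc(F)cc3)CC2)cc1` — 64.5%

Compound 2 gives the highest of the three numbers in this assay. Its nearest neighbour is compound 3, whose number lies within the scatter of that of compound 2, so no order between these two can be drawn; compound 1 stands beyond the scatter from compound 2. Among the measured compounds shown here, the one measured step, a number 19.7 percentage points higher from compound 1 to compound 3 (beyond the scatter), concerns a substituent on an aromatic carbon and leaves the group on the thiocarbonyl carbon untouched.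

Compound 4 `CC1CCCCN1C(=S)SCc1ccc(C(=O)Nc2ccccc2N)cc1` differs from compound 2 in one place: 2-methylpiperidin-1-yl in place of 2,3-dihydro-1H-indol-1-yl on a thiocarbonyl carbon. For the measured compounds named here, no measured step alters the group on the thiocarbonyl carbon, so nothing bears directly on this change; the only step available, a number 19.7 percentage points higher from compound 1 to compound 3 (beyond the scatter), shows merely that a single substituent swap can shift the read-out by a modest amount, and the three measured numbers span roughly that much. A step of modest size in either direction is therefore possible, with no firm ground to expect one beyond the scatter. Compound 4 is estimated at 55%, with a range from 35% to 75%. This corresponds to an expected step of a number 12 percentage points lower from compound 2 to compound 4 (beyond the scatter).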

Compound 4, a percentage reported as inhibition, at one concentration (the size of the read-out at that concentration, not a potency): 76.3%
Estimate against measurement, compound 4: 21.3 percentage points below; the measured number lies above the stated range.
By their numbers in this assay, from the lowest: compound 1; then compounds 3, 2 and 4 (each within the scatter of the next, the first and the last beyond it).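

In this assay, among the compounds shown here, the first measured change to the group on the thiocarbonyl carbon, 2-methylpiperidin-1-yl in place of 2,3-dihydro-1H-indol-1-yl, gives a number 9.3 percentage points higher from compound 2 to compound 4 (within the scatter), so these two groups cannot be ordered. For this pair, the group on the thiocarbonyl carbon need not contain an aromatic ring: a six-membered non-aromatic ring with fewer heavy atoms gives a number within the scatter of that of the two-ring group. No measurement offered here explains this result.

Open, as far as these compounds go, is whether the methyl group of 2-methylpiperidin-1-yl contributes to the read-out, a question piperidin-1-yl would address, and whether morpholin-4-yl or an open-chain diethylamino group on the same carbon would remain within the scatter. Also open, from the compounds shown here alone, is how compound 2 and compound 4 compare in potency, as this assay reports the size of the effect at one concentration and a concentration series would be needed to separate them.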